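Methyl on the anilino ring: outlook for compound 4

A few compounds are considered here, and "the series" means these few. Any claim that something is new, unique, unknown or untested is made for them only; others in the source may bear on it.

The shared core of compound 2 `COc1cccc(/C=C/C(=O)c2sc(Nc3ccccc3)nc2C)c1` carries an anilino group; in a functional assay on BGC-823 cells (Homo sapiens) for cytotoxicity, read by MTT assay (a lower number here means a stronger inhibitor, a higher number a weaker inhibitor), compound 2 gives 14300 nM. Compound 1 `COc1cccc(/C=C/C(=O)c2sc(Nc3cccc(C)c3)nc2C)c1` adds a methyl, the difference being (methyl in place of hydrogen on an aromatic carbon). In this assay compound 1 reaches only a limit, > 25000 nM, which is the limit of > 25000 nM in this assay, at which 1 of the 3 values shown sits. The step of an at least 1.7-fold higher number from compound 2 to compound 1 (0.24 log units; that floor lies within the scatter) therefore has a floor but no exact size. Compound 3 `Cc1nc(Nc2ccccc2)sc1C(=O)/C=C/c1ccccc1Cl` differs from compound 2 on the other side of the molecule, (2-chlorophenyl in place of 3-methoxyphenyl on a double-bonded chain carbon bound to a double-bonded chain carbon), and in this assay compound 3 gives 22800 nM, the step being a 1.6-fold higher number from compound 2 to compound 3 (0.20 log units; within the scatter). Compound 4 `Cc1ccc(Nc2nc(C)c(C(=O)/C=C/c3ccccc3Cl)s2)cc1` carries the same kind of change as compound 1 does, (methyl in place of hydrogen on an aromatic carbon), but the place is not identical: here the methyl sits para to a large group, where in compound 1 it sits meta to a large group. Starting from compound 3 and resting on the step of an at least 1.7-fold higher number from compound 2 to compound 1 (0.24 log units; that floor lies within the scatter), the expected step is a 1.4-fold higher number from compound 3 to compound 4 (0.15 log units; within the scatter), most likely again reaching a limit. For compound 4 the estimate in this assay is 32000 nM.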

Compound 4, half-maximal inhibitory concentration: > 25000 nM
Compound 4: only a limit was reported; the forecaster's own chance of this, stated with the estimate: 55%; the middle value does not contradict the limit.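

In this assay compound 4 reaches only a limit, > 25000 nM. The new step, an at least 1.0-fold higher number from compound 3 to compound 4 (0.04 log units; that floor lies within the scatter), is therefore a floor and not a size, so methyl in place of hydrogen on the anilino ring has no exact size on either core, and the two cores cannot be compared in magnitude: the same change on two cores in this assay, an at least 1.7-fold higher number (0.24 log units; that floor lies within the scatter) from compound 2 to compound 1 and an at least 1.0-fold higher number (0.04 log units; that floor lies within the scatter) from compound 3 to compound 4; the limit leaves it open whether they differ Neither methyl compound gives a measured number, so the series shows no lower number with this change on either core, yet it cannot show how large the change is or whether the place of the methyl matters: the limit of > 25000 nM in this assay, at which 2 of the 4 values shown sit.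

Still open, as far as these compounds go, is whether any group on the anilino ring gives a lower number than the plain anilino of compound 2, which gives 14300 nM. A hydroxyl, an amine or a carboxylic acid at that place on the ring would test this, provided the values fall inside the measurable range of this assay.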